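The source may hold more compounds than are shown below. What is called first, only, known or untested is meant among the compounds shown, and "the series" means these compounds.

Within this series the reference point is compound 1 `O=C(O)c1ccc2c(CN3CCC[C@H](O[C@H](CO)c4cc(Cl)cc(Cl)c4)[C@@H]3c3ccccc3)c[nH]c2c1`, which in an assay on isolated protein for activation of cGMP-dependent protein kinase 1 (Homo sapiens), read by ADP-Glo, with stated times of 120 min and 40 min (a lower number here means that less compound is needed, a higher number that more compound is needed for the effect), gives 22000 nM, the lowest of the two numbers recorded. Compound 3 `Cn1ccnc1CN1CCC[C@H](OCc2cc(Cl)cc(Cl)c2)[C@@H]1c1ccccc1` gives 165000 nM in this assay. Compound 2 `Clc1cc(Cl)cc(CO[C@H]2CCCN(Cc3ncco3)[C@H]2c2ccccc2)c1` returns only a limit of the assay, > 200000 nM. Among the measured compounds shown here, the single measured step, an at least 1.2-fold lower number from compound 2 to compound 3 (0.08 log units; that floor lies within the scatter), lies within the scatter, its floor fixed by the limit of > 200000 nM in this assay, at which 1 of the 3 values shown sits. Compound 4 `CN1CCC[C@H](O[C@H](CO)c2cc(Cl)cc(Cl)c2)[C@@H]1c1ccccc1` is compound 1 with hydrogen in place of 6-carboxy-1H-indol-3-yl on a saturated chain carbon bound to an amine nitrogen in a ring. For the measured compounds named here, no measured step covers this change; the one step known concerns a swap between 1,3-oxazol-2-yl and 1-methyl-1H-imidazol-2-yl at the same place, and compound 1, carrying 6-carboxy-1H-indol-3-yl, stands well below both. Removal of that group is expected to raise the number, the estimated step being a 6.8-fold higher number from compound 1 to compound 4 (0.83 log units; beyond the scatter). Compound 4 is therefore expected to give 150000 nM, between 40000 nM and 500000 nM, in this assay.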

Compound 4, half-maximal effective concentration: 42000 nM
Compound 4: the middle estimate sits 3.6-fold (0.55 log units) above what was measured; the measured number falls inside the stated range.
By their numbers in this assay, from the lowest: compounds 1 and 4 (each within the scatter of the next); then compound 3. At a limit, above all of these: compound 2.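

In this assay, among the compounds shown here, a 1.9-fold higher number from compound 1 to compound 4 (0.28 log units; within the scatter) is the first measured change at this place that replaces the whole 6-carboxy-1H-indol-3-yl group with hydrogen. The number for the compound with only hydrogen on this saturated chain carbon cannot be told apart from that of the compound with the 12 heavy atoms of the group. No measurement shown bears on why this is so.

Compounds 2 and 3 differ from compound 4 in more than one place, so their values cannot be set against it. Open remains whether a benzoic acid or a simple amine chain at this place would move the number beyond the scatter.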